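The source may report more compounds than this note shows. Statements on the series, on what has been measured and on what is new or still open speak of the compounds shown alone.

Compound 1, `CC(C)c1n[nH]c2c(NCc3ccc(-c4ccccn4)cc3)nc(SCCNC(=N)N)nc12`, is one of three analogues that share a core and differ only in the group carried on the saturated chain carbon bound to a sulfur. In a functional assay on HT cells (Homo sapiens) for antiproliferative activity, read by fluorescence, with a stated time of 72 h (a lower number here means a stronger inhibitor of growth, a higher number a weaker inhibitor of growth), compound 1 gives 390 nM, the second highest of the three numbers. Compound 2, `CC(C)c1n[nH]c2c(NCc3ccc(-c4ccccn4)cc3)nc(SCCn3ccnc3)nc12`, gives 155 nM, and compound 3, `C=CCSc1nc(NCc2ccc(-c3ccccn3)cc2)c2[nH]nc(C(C)C)c2n1`, gives 1010 nM.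

The step to compound 4, `CC(C)c1n[nH]c2c(NCc3ccc(-c4ccccn4)cc3)nc(SCC(O)CN3CCNCC3)nc12`, is the change (a group of 9 heavy atoms (6 carbon, 2 nitrogen, 1 oxygen; one six-membered non-aromatic ring with 2 hetero atoms) in place of a group of 5 heavy atoms (2 carbon, 3 nitrogen; no ring), on a saturated chain carbon bound to a sulfur), so the 1-hydroxy-2-(piperazin-1-yl)ethyl group is what enters.

Two measured steps from compound 1 bear on this. Moving to a five-membered aromatic ring with two hetero atoms gave a 2.5-fold lower number from compound 1 to compound 2 (0.40 log units; beyond the scatter), whereas moving to a two-carbon group without a ring gave a 2.6-fold higher number from compound 1 to compound 3 (0.41 log units; beyond the scatter); between those two, a 6.5-fold higher number from compound 2 to compound 3 (0.81 log units; beyond the scatter) separates them. A ring bearing nitrogen enters in compound 4 as well, though a non-aromatic one with an added hydroxyl, so a step in the same direction as compound 2 is expected, but of uncertain size. Compound 4 is therefore estimated at 250 nM, within a range of 100 nM to 700 nM. This would mean an expected step of a 1.6-fold lower number from compound 1 to compound 4 (0.19 log units; within the scatter).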

Compound 4, concentration for 50% growth inhibition: 332 nM
Compound 4: middle estimate off by 1.3-fold (0.12 log units), on the low side, and the stated range covers the measured number.
By their numbers in this assay, from the lowest: compound 2; then compounds 4 and 1 (each within the scatter of the next); then compound 3.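

In this assay, replacing the open-chain nitrogen group with 1-hydroxy-2-(piperazin-1-yl)ethyl leaves the number within the scatter, with a 1.2-fold lower number from compound 1 to compound 4 (0.07 log units; within the scatter), so this position accepts a much larger group carrying a six-membered non-aromatic ring without a clear change in growth inhibition. The same group compares differently with the other two substituents: measured against vinyl it gives a 3.0-fold lower number from compound 3 to compound 4 (0.48 log units; beyond the scatter), whereas measured against (1H-imidazol-1-yl)methyl it gives a 2.1-fold higher number from compound 2 to compound 4 (0.33 log units; beyond the scatter). Among the four compounds, then, the number does not simply follow the size of the group or the presence of a nitrogen-containing ring, as the group with the most heavy atoms does not give the lowest number, and the five-membered aromatic ring still does.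

The compounds shown change the hydroxyl and the piperazine ring together, leaving open what each contributes and how a morpholine ring, a simple tertiary amine or a carboxylic acid at this saturated chain carbon would read in this assay. No information given here accounts for any of these differences.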